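The compounds below may be only part of what the source reports. "The series", "measured", "known", "first", "only" and "open" are said of these compounds alone.

Measured so far:
compound 1 `O=c1cc(-c2ccccc2)oc2cccc(OCCCCN3CCC(O)CC3)c12` — 58 nM
compound 2 `CN(C)CCCCCCCCCOc1ccc2oc(-c3ccccc3)cc(=O)c2c1` — 334 nM
compound 3 `O=c1cc(-c2ccccc2)oc2ccc(OCCCN3CCC(O)CC3)cc12` — 130 nM

In an assay on isolated protein (Cavia porcellus) with Sigma non-opioid intracellular receptor 1 (Homo sapiens) as the target, read by radioligand binding (on this read-out lower numbers stand for stronger inhibition and higher numbers for weaker inhibition), compound 2 stands at the highest of the three numbers. Its nearest neighbour is compound 3, reached by a 2.6-fold lower number from compound 2 to compound 3 (0.41 log units; beyond the scatter). Compound 1 lies furthest from it, giving 58 nM in this assay, while compound 2 gives 334 nM.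

The next compound, compound 4 `CN(CCCCCCOc1ccc2oc(-c3ccccc3)cc(=O)c2c1)Cc1ccccc1`, is derived from compound 2 by the change (benzyl(methyl)amino in place of 3-(dimethylamino)propyl on a saturated chain carbon, six bonds along the chain from an oxygen on an aromatic ring). Among the compounds with values here, the one measured step that touches the same chain is a 2.6-fold lower number from compound 2 to compound 3 (0.41 log units; beyond the scatter), which shortened the linker and at the same time exchanged the amine for 4-hydroxypiperidin-1-yl, so it is not a clean precedent. Within the data shown here, no measured pair sets benzyl(methyl)amino against a dimethylamino group alone. The shortening of the chain shared with that step argues for a somewhat lower number, and the added ring is left uncovered by the data; the expected step is therefore a 2.8-fold lower number from compound 2 to compound 4 (0.44 log units; beyond the scatter), a modest move toward a lower number rather than none at all. For compound 4 the estimate in this assay is 120 nM, with a range from 40 nM to 400 nM.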

Compound 4, half-maximal inhibitory concentration: 52 nM
Compound 4: middle estimate off by 2.3-fold (0.36 log units), on the high side; measured number inside the range.
By their numbers in this assay, from the lowest: compounds 4 and 1 (each within the scatter of the next); then compound 3; then compound 2.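

In this assay, placing benzyl(methyl)amino on a saturated chain carbon, six bonds along the chain from an oxygen on an aromatic ring, in place of 3-(dimethylamino)propyl gives a 6.4-fold lower number from compound 2 to compound 4 (0.81 log units; beyond the scatter) as the measured step. Compared with the earlier step, a 2.6-fold lower number from compound 2 to compound 3 (0.41 log units; beyond the scatter), which brought in 4-hydroxypiperidin-1-yl in place of 6-(dimethylamino)hexyl, this one shows that a group with a six-membered aromatic ring of carbon only, 9 heavy atoms in place of 6, is also accepted here with a lower number, so both listed replacements on compound 2 move the same way and neither goes against that direction. The data at hand give no explanation for the size or direction of this step.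

The compounds shown leave open how much of the step belongs to the benzyl group and how much to the shorter distance from the chain to the amine nitrogen, since the change alters both at once, and a plain methylamino group or a longer chain carrying benzyl(methyl)amino would separate the two. Also open, as far as these compounds go, is how a fluorobenzyl or a phenethyl group would read on the chain of compound 4 in this assay, and whether 4-hydroxypiperidin-1-yl would fit on that same chain.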